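The source may hold more compounds than are shown below. What is called first, only, known or untested is meant among the compounds shown, and "the series" means these compounds.

Measured compounds:

- compound 1 `c1ccc(-c2ccc(OC[C@@H]3CCN3)cn2)cc1`: 2.3 nM
- compound 2 `Brc1cncc(OC[C@@H]2CCN2)c1`: 0.18 nM

In an assay on brain for binding affinity to Neuronal acetylcholine receptor; alpha4/beta2 (Rattus norvegicus), read by radioligand binding (on this read-out higher numbers stand for weaker inhibition and lower numbers for stronger inhibition), compound 2 gives the lower of the two numbers on record; compound 1 gives a higher number, and the gap between them lies beyond the scatter. Compound 3 `CCc1cncc(OC[C@@H]2CCN2)c1` has not been measured. It differs from compound 2 in one place: ethyl in place of bromo on an aromatic carbon of the six-membered aromatic ring with one nitrogen, two atoms from the ring nitrogen.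

For the measured compounds named here, no step between two measured compounds covers this exchange, so the size of the step cannot be read from the numbers at hand. The substituent at this position is retained in size and kept uncharged, and the rest of the molecule is unchanged. The expectation is therefore a small step upward in this assay, most likely within the scatter or only just beyond it, rather than a return to the number of compound 1. Compound 3 is estimated at 0.8 nM, with a range from 0.2 nM to 4 nM. The estimated step of a 4.4-fold higher number from compound 2 to compound 3 (0.65 log units; beyond the scatter) is expected to be small.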

Compound 3, inhibition constant: 0.1 nM
For compound 3 the middle estimate is 8.0-fold (0.90 log units) above the measured one; measured number outside the range, below it.
By their numbers in this assay, from the lowest: compounds 3 and 2 (each within the scatter of the next); then compound 1.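

In this assay, ethyl in place of bromo on an aromatic carbon, two atoms from the ring nitrogen, gives a 1.8-fold lower number from compound 2 to compound 3 (0.26 log units; within the scatter), so this exchange leaves the read-out unresolved from that of the bromo compound. For the compounds shown here, this is the first step that isolates this position, and it shows that the position accepts ethyl as well as bromo while the number stays in the same sub-nanomolar range. Neither group carries a ring, a net charge, a hydrogen-bond donor or a hydrogen-bond acceptor, and nothing on record bears on why the two read alike.

Going by these compounds, the limits of this tolerance remain open: a longer chain such as butyl, a ring such as phenyl, or an amine or a carboxylic acid at the same place could each hold the number or move it well beyond the scatter. Also open, on these data alone, is whether ethyl and bromo would still read alike on another core, such as that of compound 1, or at another receptor.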